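Amide chain variation in an antiproliferative series

A few compounds are considered here, and "the series" means these few. Any claim that something is new, unique, unknown or untested is made for them only; others in the source may bear on it.

compound 1 `CCCCCCCCCCCCCCNC(=O)[C@@H]1CSC(c2ccc(NC(C)=O)cc2)N1`: 2300 nM
compound 2 `CCCCCCCCCCCCCCCCCNC(=O)[C@@H]1CSC(c2ccc(NC(C)=O)cc2)N1`: 8500 nM

Within the data shown here, in a functional assay on cells (Homo sapiens) for antiproliferative activity, read by sulforhodamine B assay, with a stated time of 48 h (on this read-out higher numbers stand for weaker inhibition and lower numbers for stronger inhibition), compound 2 holds the highest number of the two measured; the only step, a 3.7-fold higher number from compound 1 to compound 2 (0.57 log units; beyond the scatter), came from extra carbons on the same chain. Compound 3 `CCCCCCCCC/C=C\CCCCCCCNC(=O)[C@@H]1CSC(c2ccc(NC(C)=O)cc2)N1` carries a group of 11 heavy atoms (11 carbon; no ring) in place of a group of 10 heavy atoms (10 carbon; no ring), on a saturated chain carbon, seven bonds along the chain from an amide-type nitrogen. Among the measured compounds shown here, that one step bears on it, since compound 3 again extends the chain, but the double bond has no precedent here. A small further rise or none beyond the scatter is expected, as a 1.2-fold higher number from compound 2 to compound 3 (0.07 log units; within the scatter). Compound 3 is therefore estimated at 10000 nM, within 4000 nM to 25000 nM.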

Compound 3, half-maximal inhibitory concentration: 1400 nM
Compound 3: middle estimate off by 7.1-fold (0.85 log units), on the high side, and the stated range ends above it.
By their numbers in this assay, from the lowest: compounds 3 and 1 (each within the scatter of the next); then compound 2.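

In this assay, lengthening the chain at this position does not always go with a higher number: a 6.1-fold lower number from compound 2 to compound 3 (0.78 log units; beyond the scatter) runs against a 3.7-fold higher number from compound 1 to compound 2 (0.57 log units; beyond the scatter), and the entering group is the one that carries a double bond outside aromatic rings. Against the shorter chain, a 1.6-fold lower number from compound 1 to compound 3 (0.22 log units; within the scatter), so compound 3 and compound 1 cannot be told apart. No measurement at hand accounts for the turn. The compounds shown leave open whether the double bond or the chain length carries the step; a saturated chain of the same length would separate the two. As far as these compounds go, a carboxylic acid or an amine at the chain end also remains open.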